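The source may hold more compounds than are shown below. What is called first, only, known or untested is meant among the compounds shown, and "the series" means these compounds.

Measured in an ADME assay on A549 cells (Homo sapiens) for cytotoxicity, read by MTT assay; a higher number here means that more compound is needed for the effect, a lower number that less compound is needed:
- compound 1 `C=C1CCCC(C)(C)[C@@H]1C[C@H](O)/C(C)=C/CC[C@@H]1[C@@]2(C)CCCC(C)(C)[C@@H]2CC[C@@]1(C)O`: 6.4 ug/mL
- compound 2 `C=C1CCCC(C)(C)[C@@H]1C[C@@H](O)/C(C)=C/CC[C@@H]1[C@@]2(C)CCCC(C)(C)[C@@H]2CC[C@@]1(C)O`: > 10 ug/mL (a limit)
- compound 3 `C=C1CCCC(C)(C)[C@@H]1CC(=O)/C(C)=C/CC[C@@H]1[C@@]2(C)CCCC(C)(C)[C@@H]2CC[C@@]1(C)O`: 5.3 ug/mL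

Compound 1 and compound 3 lie within the scatter of each other, and the entry for compound 2 is a limit, not a number. Compound 4 `C=C1CCCC(C)(C)[C@@H]1C[C@H](OC(=O)c1ccccc1)/C(C)=C/CC[C@@H]1[C@@]2(C)CCCC(C)(C)[C@@H]2CC[C@@]1(C)O` is compound 1 with one change, (benzoyl in place of hydrogen on an oxygen on a saturated carbon), which reads as hydroxy to benzoyloxy. Among the measured compounds shown here, only one measured step is at hand, an at least 1.5-fold higher number from compound 1 to compound 2 (0.19 log units; that floor lies within the scatter), and it rests on the limit of > 10 ug/mL in this assay, at which 1 of the 3 values shown sits, and on (the fact that compounds 1 and 2 differ only in the configuration as drawn). That step adds no benzoyl, so it gives no direction, and no shift beyond the scatter is expected in this assay. The expected change is a 1.1-fold higher number from compound 1 to compound 4 (0.04 log units; within the scatter). For compound 4 the estimate is 7 ug/mL, with an expected range from 3 ug/mL to 15 ug/mL.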

Compound 4, concentration for half-maximal effect: > 10 ug/mL
Compound 4 gave a limit, no number (the forecaster's own chance of this, stated with the estimate: 30%); middle value at least 1.4-fold (0.15 log units) away from the limit.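

In this assay, benzoyl in place of hydrogen on this oxygen gives an at least 1.5-fold higher number from compound 1 to compound 4 (0.19 log units; that floor lies within the scatter). As far as these compounds go, compound 4 gives > 10 ug/mL, which is a limit and not a number, so the size of this step remains unknown and its floor does not pass the scatter: the limit of > 10 ug/mL in this assay, at which 2 of the 4 values shown sit. Among the compounds shown here, the step still gives this oxygen a direction that the earlier compounds did not, since hydroxy to benzoyloxy brings no lower number. From the compounds shown here alone, whether compound 4 lies far past its limit remains open. So does how an acetyl group on this oxygen, or an amine in place of the hydroxy, would read in this assay.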